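Trimming the chain: compound 3 to compound 4

The source may report more compounds than this note shows. Statements on the series, on what has been measured and on what is new or still open speak of the compounds shown alone.

Compound 1 `CC(C)COc1ccccc1C1CC(=O)c2ccccc2O1` gives 33200 nM
Compound 2 `C=CCOc1ccccc1C1CC(=O)c2ccccc2O1` gives 38600 nM
Compound 3 `CCCCCOc1ccccc1C1CC(=O)c2ccccc2O1` gives 39300 nM

In a functional assay on J774.A1 cells (Mus musculus) for inhibition, read by Griess assay, with stated times of 1 h and 24 h (on this read-out lower numbers stand for stronger inhibition and higher numbers for weaker inhibition), compound 3 cannot be separated from the other two measured compounds: a 1.0-fold higher number from compound 2 to compound 3 (0.01 log units; within the scatter) and a 1.2-fold higher number from compound 1 to compound 3 (0.07 log units; within the scatter). Compound 4 `CCCCOc1ccccc1C1CC(=O)c2ccccc2O1` is the next case, and its difference from compound 3 is hydrogen in place of methyl on a saturated chain carbon, four bonds along the chain from an oxygen on an aromatic ring. In words, this is hydrogen in place of methyl on a saturated chain carbon, four bonds along the chain from an oxygen on an aromatic ring.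

Within the data shown here, no measured step is this exact change. The nearest evidence is the three steps above that exchange the group on a saturated chain carbon bound to an oxygen on an aromatic ring. The third of them is a 1.2-fold higher number from compound 1 to compound 2 (0.07 log units; within the scatter), and none of the three leaves the scatter. No step beyond the scatter is therefore expected in this assay, in either direction. The estimated step is a 1.1-fold lower number from compound 3 to compound 4 (0.03 log units; within the scatter).

Compound 4 is expected at 37000 nM, with an estimated range from 24000 nM to 55000 nM.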

Compound 4, half-maximal inhibitory concentration: 47700 nM
For compound 4 the middle estimate is 1.3-fold (0.11 log units) below the measured one; the range from low to high includes it.
By their numbers in this assay, from the lowest: compounds 1, 2, 3 and 4 (each within the scatter of the next).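

In this assay, among these compounds, hydrogen in place of methyl on a saturated chain carbon, four bonds along the chain from an oxygen on an aromatic ring, gives a 1.2-fold higher number from compound 3 to compound 4 (0.08 log units; within the scatter) and is the first reading of a change this far out along the chain. Compound 4 also stays within the scatter of the two other chains: propyl in place of vinyl gives a 1.2-fold higher number from compound 2 to compound 4 (0.09 log units; within the scatter) and propyl in place of isopropyl gives a 1.4-fold higher number from compound 1 to compound 4 (0.16 log units; within the scatter), so the four compounds cannot be separated from one another. No supporting data bear on this result.

These compounds do not show whether any change to this chain can move the number beyond the scatter. An amine or a carboxylic acid at the chain end, or a longer chain, remains an open case.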